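Swapping the Acid-Bearing Ring for a Cyclic Sulfone

A few compounds are considered here, and "the series" means these few. Any claim that something is new, unique, unknown or untested is made for them only; others in the source may bear on it.

compound 1, `O=C(O)C1CCC(O)(C(=O)N2CC[C@](c3ccc(C(F)(C(F)(F)F)C(F)(F)F)cc3)(S(=O)(=O)c3ccc(F)cc3)C2)CC1`: 99%; 98% (2 entries)
compound 2, `C[C@]1(C(=O)N2CC[C@](c3ccc(C(F)(C(F)(F)F)C(F)(F)F)cc3)(S(=O)(=O)c3ccc(F)cc3)C2)CC[C@@H](C(=O)O)CC1`: 100%
compound 3, `O=C1NC(=O)C2(CCC(C(=O)N3CC[C@](c4ccc(C(F)(C(F)(F)F)C(F)(F)F)cc4)(S(=O)(=O)c4ccc(F)cc4)C3)CC2)N1`: 81%; 82% (2 entries)

In an ADME assay on microsomes from liver (Mus musculus) for metabolic stability, with a stated time of 10 min (on this read-out lower numbers stand for a less stable compound and higher numbers for a more stable compound), compound 1 gives 99%; 98% (2 entries), compound 2 gives 100% and compound 3 gives 81%; 82% (2 entries). Compound 2 stands with the only number shown for it; two further entries gave no single number. Compounds 1 and 2 sit at the top of the scale (the several entries of compound 1 in this assay, 99%; 98% (2 entries)), while compound 3 sits clearly lower (the several entries of compound 3 in this assay, 81%; 82% (2 entries)). The unmeasured compound 4, `O=C(C1CCS(=O)(=O)CC1)N1CC[C@](c2ccc(C(F)(C(F)(F)F)C(F)(F)F)cc2)(S(=O)(=O)c2ccc(F)cc2)C1`, differs from compound 2 in one place: 1,1-dioxothian-4-yl in place of 4-carboxy-1-methylcyclohexyl on a carbonyl carbon. Among the measured compounds shown here, no measured pair shows this change, so its effect is a matter of expectation only. In this assay a moderate step downwards is expected, beyond the usual scatter, with compound 4 still fairly stable. Compound 4 is expected to give 85%, with a range from 68% to 98%. This corresponds to an expected step of a number 15 percentage points lower from compound 2 to compound 4 (beyond the scatter).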

Compound 4, percent of the compound remaining: 96%
Compound 4: the middle estimate sits 11 percentage points below what was measured; the measured number falls inside the stated range.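

In this assay, placing 1,1-dioxothian-4-yl on the carbonyl carbon in place of 4-carboxy-1-methylcyclohexyl gives a number 4 percentage points lower from compound 2 to compound 4 (within the scatter). This is the only pair shown that differs in one place, and it shows that this position tolerates losing the carboxy group without a change that stands out from the scatter. Nothing measured here explains why the read-out holds.

The compounds shown leave open how a ring carrying an amine or a longer open chain would behave on this same carbonyl carbon.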